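The source may report more compounds than this note shows. Statements on the series, on what has been measured and on what is new or still open speak of the compounds shown alone.

Measured compounds in a functional assay on HepG2 cells (Homo sapiens) for antiproliferative activity, read by MTT assay, with a stated time of 48 h; on this read-out lower numbers stand for stronger inhibition and higher numbers for weaker inhibition:
Compound 1 `N#CC1=C(N)Oc2c(c3nc4ccccc4nc3c3ccccc23)C12C(=O)N(Cc1cnnn1-c1ccc([N+](=O)[O-])cc1)c1ccccc12` gives > 50000 nM.
Compound 2 `N#CC1=C(N)Oc2c(c3nc4ccccc4nc3c3ccccc23)C12C(=O)N(Cc1cnnn1-c1ccc(F)c(Cl)c1)c1ccccc12` gives > 50000 nM.

Both of these values are limits of the assay, not numbers. For compound 1 the reading > 50000 nM is a limit only. For compound 2 the reading > 50000 nM is likewise a limit only. Compound 2 therefore stands at the limit, together with compound 1 (the limit of > 50000 nM in this assay, at which 2 of the 2 values shown sit), and the step that the two limits leave unreadable from compound 1 to compound 2 cannot be read in size or direction.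

Compound 3 `N#CC1=C(N)Oc2c(c3nc4ccccc4nc3c3ccccc23)C12C(=O)N(Cc1cnnn1-c1cc(Cl)ccc1Cl)c1ccccc12` differs from compound 2 in one place: 2,5-dichlorophenyl in place of 3-chloro-4-fluorophenyl on an aromatic nitrogen. For the measured compounds named here, the only measured step that bears on this position, the exchange of one substituted phenyl on the aromatic nitrogen for another, is the one from compound 1 to compound 2, and it is unreadable. Going by the values given here, no measured step therefore tells how large a change to expect in this assay; the two values shown give no number to move from.

Compound 3 is expected to remain at or near the limit, with a step that the limit leaves unreadable from compound 2 to compound 3 that is not readable beyond the scatter. The estimate for compound 3 in this assay is 60000 nM, ranging from 15000 nM to 250000 nM.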

Compound 3, half-maximal inhibitory concentration: > 50000 nM
Compound 3 gave a limit, no number; the forecaster's own chance of this, stated with the estimate: 80%; the middle value does not contradict the limit.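

No new step can be read from compound 3: like compound 1 and compound 2, it gives only a limit in this assay, so the steps among these three compounds cannot be read, and all three stand at the same point: the limit of > 50000 nM in this assay, at which 3 of the 3 values shown sit.

The compounds shown leave open whether any substituted phenyl at this place could bring the read-out off the limit, and by how much.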